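Carbamate, benzamide and urea variants on the shared core

This account rests on a few compounds, and the source may have more. Where it says the series, first, only, none or still open, it means among the compounds named here.

Measured so far in a functional assay on A549 cells (Homo sapiens) for cytotoxicity, read by MTT assay; on this read-out lower numbers stand for stronger inhibition and higher numbers for weaker inhibition:
compound 1 `CCc1cc(S(=O)(=O)N2C[C@H](c3ccccc3)NC2=O)ccc1NC(=O)OC(C)C`: 60 nM
compound 2 `CCc1cc(S(=O)(=O)N2C[C@H](c3ccccc3)NC2=O)ccc1NC(=O)c1ccc([N+](=O)[O-])cc1`: 700 nM
compound 3 `CCOC(=O)Nc1ccc(S(=O)(=O)N2C(=O)N[C@@H](c3ccccc3)C2C)cc1Cl`: 6000 nM

Compound 2 stands second highest of the three numbers in this assay; compound 1 sits well below it, and compound 3 well above it, both gaps beyond the scatter. Compound 3 differs from the others in more than one place, so its value is noted without a step.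

Compound 4 `CCc1cc(S(=O)(=O)N2C[C@H](c3ccccc3)NC2=O)ccc1NC(=O)NC(C)C` is not yet measured. It differs from compound 2 by isopropylamino in place of 4-nitrophenyl on a carbonyl carbon. Going by the values given here, the one measured step that bears on this is a 12-fold higher number from compound 1 to compound 2 (1.07 log units; beyond the scatter), where isopropoxy on the same carbonyl carbon gave the lower number. Isopropylamino returns a small, ring-free group of that kind, so a step back downward of roughly that size is expected, with the residual uncertainty that an amine-type linker is not the same as the ester-type one of compound 1. Compound 4 is therefore expected near 100 nM, within 35 nM to 300 nM, which means an expected step of a 7.0-fold lower number from compound 2 to compound 4 (0.85 log units; beyond the scatter).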

Compound 4, half-maximal inhibitory concentration: 100 nM
For compound 4 middle estimate and measured number coincide at the digits printed; measured number inside the range.
By their numbers in this assay, from the lowest: compounds 1 and 4 (each within the scatter of the next); then compound 2; then compound 3.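

Replacing 4-nitrophenyl with isopropylamino on this carbonyl carbon gives a 7.0-fold lower number from compound 2 to compound 4 (0.85 log units; beyond the scatter) in this assay and shows that the low number is not confined to the isopropoxy carbamate. A second small, ring-free group now reaches the same range. Going by these compounds alone, exchanging isopropoxy for isopropylamino gives a 1.7-fold higher number from compound 1 to compound 4 (0.22 log units; within the scatter) in this assay and does not separate the carbamate from the urea, leaving compound 2 as the one member of these three with a ring at this position and a number apart from the other two.

Going by these compounds, whether the higher number of compound 2 follows the ring or its nitro group stays open; a plain phenyl or a longer chain such as n-butyl on this carbonyl carbon would help to separate these possibilities. The data shown give no measured basis for explaining any of these differences.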